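Swapping trifluoromethyl for methoxy on a shared core

A few compounds are considered here, and "the series" means these few. Any claim that something is new, unique, unknown or untested is made for them only; others in the source may bear on it.

Measured compounds:
compound 1 `Nc1nc(-c2ccc(Cc3ccc(C(F)(F)F)cc3)cc2)cs1`, 1390 nM
compound 2 `COc1ccc(Cc2ccccc2)cc1`, 4830 nM
compound 3 `COc1cccc(Cc2ccc(-c3csc(N)n3)cc2)c1`, 5920 nM

In an assay on cells for activation of leukotriene A-4 hydrolase (Homo sapiens), with a stated time of 10 min (on this read-out higher numbers stand for an effect only at larger amounts of compound and lower numbers for an effect already at smaller amounts), compound 1 gives the lowest of the three numbers; compound 2 sits a little above it and compound 3 further above, both gaps beyond the scatter.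

Compound 4 `COc1ccc(Cc2ccc(-c3csc(N)n3)cc2)cc1` has not yet been measured. It differs from compound 1 in one place: methoxy in place of trifluoromethyl on an aromatic carbon. Among the compounds with values here, no measured pair shows this exact step. Two of the three measured compounds carry a methoxy group, and both gave higher numbers than compound 1, so a step upward beyond the scatter is expected, not a small one.

For compound 4 the estimate in this assay is 4500 nM (range 1500 nM to 14000 nM), because compound 3 gives 5920 nM; the expected step is a 3.2-fold higher number from compound 1 to compound 4 (0.51 log units; beyond the scatter).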

Compound 4, concentration for half-maximal activity: 210 nM
For compound 4 the middle estimate is 21-fold (1.33 log units) above the measured one, and the stated range ends above it.
By their numbers in this assay, from the lowest: compound 4; then compound 1; then compounds 2 and 3 (each within the scatter of the next).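

In this assay, within the data shown here, methoxy in place of trifluoromethyl on this aromatic carbon, para to a large group, gives a 6.6-fold lower number from compound 1 to compound 4 (0.82 log units; beyond the scatter) and so shows that methoxy at this place goes with the lower number, which the earlier compounds did not reveal. Adding 2-amino-1,3-thiazol-4-yl in place of hydrogen on an aromatic carbon gives a 23-fold lower number from compound 2 to compound 4 (1.36 log units; beyond the scatter) and shows that this group also matters once methoxy is present. Nothing available here explains either step. As far as these compounds go, whether an ethoxy group, a hydroxyl or an amine at the same carbon would give a still lower number stays open.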